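Pyridin-3-yl in place of pyridin-4-yl on the carbonyl carbon

The source may hold more compounds than are shown below. What is called first, only, known or untested is meant among the compounds shown, and "the series" means these compounds.

In a functional assay on MDA-MB-231 cells (Homo sapiens) for antiproliferative activity, with a stated time of 4 days (a lower number here means a stronger inhibitor, a higher number a weaker inhibitor), compound 1 (`CCCCc1ccc2[nH]c(-c3ccc(C(F)(F)F)cc3)c(/C=N/NC(=O)c3ccncc3)c2c1`) gives 94 nM and compound 2 (`CCCCc1ccc2[nH]c(-c3ccc(CC)cc3)c(/C=N/NC(=O)c3ccncc3)c2c1`) gives 80 nM. Among the measured compounds shown here, the measured step is a 1.2-fold lower number from compound 1 to compound 2 (0.07 log units; within the scatter), so compound 2 stands level with the only other measured compound, and the two values cannot be told apart.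

Compound 3 (`CCCCc1ccc2[nH]c(-c3ccc(CC)cc3)c(/C=N/NC(=O)c3cccnc3)c2c1`) has the same atoms as compound 2, joined differently: pyridin-3-yl in place of pyridin-4-yl on a carbonyl carbon, (pyridin-3-yl in place of pyridin-4-yl on a carbonyl carbon). For the measured compounds named here, no measured pair differs at this place. Going by the values given here, the single available step, a 1.2-fold lower number from compound 1 to compound 2 (0.07 log units; within the scatter), is ethyl in place of trifluoromethyl on an aromatic carbon, so it says little about this change beyond showing that one substitution elsewhere left this assay within the scatter. The data therefore support no direction for the new step, and the estimate stays close to compound 2 with a wide range.

The expected change is a 1.4-fold higher number from compound 2 to compound 3 (0.14 log units; within the scatter), and no shift beyond the scatter is anticipated. For compound 3 the estimated value is 110 nM, with an expected range of 35 nM to 350 nM.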

Compound 3, half-maximal inhibitory concentration: 53 nM
Beside the measured number, compound 3's estimate is 2.1-fold (0.32 log units) above it; the measured number falls inside the stated range.
By their numbers in this assay, from the lowest: compounds 3, 2 and 1 (each within the scatter of the next).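

Notes on the carbonyl position: in this assay, the first step read at this place, pyridin-3-yl in place of pyridin-4-yl on a carbonyl carbon, is a 1.5-fold lower number from compound 2 to compound 3 (0.18 log units; within the scatter). The series to this point had varied only the group carrying ethyl or trifluoromethyl, and it now shows that the pyridine at the carbonyl carbon can be joined through either of these two ring positions with no shift that can be separated from the scatter, although the heavy-atom, donor and acceptor counts are the same on both sides, so this exchange probes only the way the ring is joined. No supporting measurement is at hand that would account for this result or connect it to any property of the two groups.

Still open, from the compounds shown here alone, is whether pyridin-2-yl, a plain phenyl ring or a saturated piperidine ring on the same carbonyl carbon would stay within the scatter of compound 2 and compound 3. Also open, going by these compounds, is whether the exchange of pyridin-4-yl for pyridin-3-yl reads the same when trifluoromethyl, as in compound 1, replaces ethyl.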